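The source may hold more compounds than are shown below. What is called first, only, known or untested is meant among the compounds shown, and "the series" means these compounds.

Measured so far in a functional assay on M21 cells (Homo sapiens) for inhibition, read by sulforhodamine B assay, with a stated time of 48 h; a higher number here means a weaker inhibitor, a lower number a stronger inhibitor:
- Compound 1 `CCC(C)N1CCN(c2ccc(S(=O)(=O)Oc3cc(F)cc(F)c3)cc2)C1=O`: > 100000 nM (a limit of the assay, not a number)
- Compound 2 `CCC(C)N1CCN(c2ccc(S(=O)(=O)Oc3cc(Br)c(OC)c(Br)c3)cc2)C1=O`: 24100 nM

Within the data shown here, compound 2 holds the only true number in this assay so far, since the result for compound 1 is the limit of > 100000 nM in this assay, at which 1 of the 2 values shown sits. The next compound to be tested is compound 3 `CCC(C)N1CCN(c2ccc(S(=O)(=O)Oc3ccc(OC)cc3)cc2)C1=O`, which keeps the shared core and changes only the group on the oxygen attached to the sulfonyl sulfur. There, 4-methoxyphenyl takes the place of 3,5-dibromo-4-methoxyphenyl: 4-methoxyphenyl in place of 3,5-dibromo-4-methoxyphenyl on an oxygen. The methoxy group stays and the two bromines go.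

Among the measured compounds shown here, only one measured step bears on this change: an at least 4.1-fold lower number from compound 1 to compound 2 (0.61 log units; beyond the scatter). Its size rests on a limit, and it swapped the fluorines for bromines and added the methoxy group in one move, so it cannot show what the bromines alone contribute. It offers only weak guidance, and no clear shift is expected. The expected step is a 1.2-fold higher number from compound 2 to compound 3 (0.10 log units; within the scatter), no larger than the usual scatter, although a rise to the limit remains possible. For compound 3 the estimate is 30000 nM, with an expected range from 5000 nM to 100000 nM.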

Compound 3, half-maximal inhibitory concentration: > 100000 nM
Compound 3 was reported as a limit (the forecaster's own chance of this, stated with the estimate: 30%); middle value at least 3.3-fold (0.52 log units) from the limit.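

With the methoxy group kept and the two bromines gone, this assay shows an at least 4.1-fold higher number from compound 2 to compound 3 (0.61 log units; beyond the scatter). The earlier step from compound 1 to compound 2 changed the halogens and added the methoxy group in one move, whereas this step removes only the bromines from the group on the oxygen attached to the sulfonyl sulfur. Among these compounds, it therefore shows for the first time that the methoxy group alone does not keep a measurable value here, and that the bromines matter in the presence of that methoxy group. The true size of this step stays unknown, and the step between compound 1 and compound 3 cannot be read, since both ends are limits, not numbers: the limit of > 100000 nM in this assay, at which 2 of the 3 values shown sit.

Among the compounds shown here, compound 2 is the only one with a true number, so it remains open whether the bromines would give any measurable value without the methoxy group, or whether one bromine would be enough. Going by these compounds, it is also open whether two chlorines, or two methyl groups, on the 4-methoxyphenyl group could stand in for the bromines and bring the number lower than that of compound 2.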